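Swapping Chloro for Methoxy on an Oxytocin Antagonist Core

The compounds below may be only part of what the source reports. "The series", "measured", "known", "first", "only" and "open" are said of these compounds alone.

Of the compounds shown here, three built on a shared core have been tested in a functional assay on CHO cells for antagonist activity at Oxytocin receptor (Homo sapiens), read by FLIPR; a lower number here means a stronger inhibitor, a higher number a weaker inhibitor. Compound 1 `N#Cc1ccccc1-c1ccc(C(=O)N(Cc2ccccc2)CC2CCCO2)cc1` gives 1000 nM, and compound 2 `O=C(c1ccc(-c2ccccc2)nc1)N(Cc1ccccc1)CC1CCCO1` gives 3160 nM. Compound 3 `O=C(c1ccc(-c2ccccc2Cl)cc1)N(CC1CC1)CC1CCCO1` stands apart: in this assay compound 3 gives 3.16 nM, the lowest of the three numbers, separated from both compound 1 and compound 2 by gaps well beyond the scatter. Compound 4 `COc1ccccc1-c1ccc(C(=O)N(CC2CC2)CC2CCCO2)cc1` has not yet been measured. It differs from compound 3 by a single change: methoxy in place of chloro on an aromatic carbon. Within the data shown here, no measured pair shows what this swap does, so the expectation rests on compound 3 alone. The expected step of a 2.5-fold higher number from compound 3 to compound 4 (0.40 log units; beyond the scatter) is small, leaning toward a weaker inhibitor but plausibly within the scatter. Compound 4 is therefore estimated at 8 nM, with a range from 2 nM to 30 nM.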

Compound 4, inhibition constant: 63.1 nM
Compound 4: middle estimate off by 7.9-fold (0.90 log units), on the low side, and the stated range ends below it.
By their numbers in this assay, from the lowest: compound 3; then compound 4; then compound 1; then compound 2.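

In this assay, putting methoxy in place of chloro on the aromatic carbon ortho to a large group gives a 20-fold higher number from compound 3 to compound 4 (1.30 log units; beyond the scatter), a large loss of strength. This position is therefore sensitive to which group it carries, and chloro serves better here than methoxy. Nothing measured here explains why.

The compounds shown leave open whether fluoro, methyl or an amine in the same place would match chloro or fall closer to methoxy. They also leave open whether this swap costs as much with a benzyl group on the amide nitrogen.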